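Solubility notes: one side group exchanged

The compounds below may be only part of what the source reports. "The series", "measured", "known", "first", "only" and "open" are said of these compounds alone.

Of the compounds shown here, two have numbers so far in a physicochemical assay for solubility, read by HPLC, in phosphate buffer, at pH 6.5 (a higher number here means a more soluble compound, a lower number a less soluble compound), and they set the frame for this step. Compound 1 (`COC(=O)C1=C(C)NC(c2nccs2)=N[C@]1(C)c1ccc(F)cc1`) gives 178 ug/mL in these notes. Compound 2 (`COC(=O)C1=C(CN2CC3CC2CO3)NC(c2nccs2)=NC1(C)c1ccc(F)cc1`) gives 564 ug/mL as the higher of the two numbers, and the gap between them lies beyond the usual scatter. Among the compounds with values here, no measured pair differs in one place only, so the series offers no direct guide to the size of a single exchange.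

Compound 3 (`COC(=O)C1=C(CN2CCCS2(=O)=O)NC(c2nccs2)=NC1(C)c1ccc(F)cc1`) has not yet been measured. It differs from compound 2 by a group of 7 heavy atoms (3 carbon, 1 nitrogen, 2 oxygen, 1 sulfur; one five-membered non-aromatic ring with 2 hetero atoms) in place of a group of 7 heavy atoms (5 carbon, 1 nitrogen, 1 oxygen; 2 five-membered non-aromatic rings with 1 hetero atom each), on a saturated chain carbon bound to a double-bonded ring carbon with the rest of the structure unchanged. Within the data shown here, the only number for a compound without the leaving group is that of compound 1 at 178 ug/mL and a fall towards that level is the working expectation. The expected change in this assay is a 2.8-fold lower number from compound 2 to compound 3 (0.45 log units; beyond the scatter) as a downward step, probably beyond the scatter but only loosely estimated. Compound 3 is estimated at 200 ug/mL with an expected range from 70 ug/mL to 480 ug/mL as the working figures.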

Compound 3, solubility: 125 ug/mL
The estimate for compound 3 lay 1.6-fold (0.20 log units) above the measured number; measured number inside the range.
By their numbers in this assay, from the lowest: compounds 3 and 1 (each within the scatter of the next); then compound 2.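

In this assay, the series now has its first exchange in one place: on a saturated chain carbon bound to a double-bonded ring carbon, the change gives a 4.5-fold lower number from compound 2 to compound 3 (0.65 log units; beyond the scatter), a step beyond the scatter. The read-out at this position therefore depends on which ring group it carries, even though the leaving and entering groups match in their counts of 7 heavy atoms, 0 hydrogen-bond donors and 2 hydrogen-bond acceptors, and neither carries a net charge. They differ in their atoms and rings, with 2 five-membered non-aromatic rings with 1 hetero atom each leaving, and one five-membered non-aromatic ring with 2 hetero atoms and 2 double bonds outside aromatic rings entering, but no measurement here ties the step to any of these differences.

A single exchange cannot show whether the same step would appear with other groups at this position or on another core. From the compounds shown here alone, how this assay would read with an open-chain group such as dimethylamino, a carboxylic acid or a longer chain on this carbon remains open.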